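The compounds below may be only part of what the source reports. "The series", "measured", "known", "first", "only" and "open" are said of these compounds alone.

Compound 1 `COc1ccc(C2=NOC(COc3ccc(-c4nnnn4-c4cc(OC)c(OC)c(OC)c4)cc3N)C2)cc1OC`: 2520 nM
Compound 2 `COc1cc(C2=NOC(COc3ccc(-c4nnnn4-c4cc(OC)c(OC)c(OC)c4)cc3N)C2)cc(OC)c1OC`: 2060 nM
Compound 3 `COc1ccc(C2=NOC(COc3ccc(-c4nnnn4-c4cc(OC)c(OC)c(OC)c4)cc3N)C2)cc1O`: 2130 nM

These values come from a functional assay on A549 cells (Homo sapiens) for cytotoxicity, read by MTT assay, with a stated time of 48 h; on this read-out higher numbers stand for weaker inhibition and lower numbers for stronger inhibition. Compound 3 cannot be told apart from the other two: a 1.0-fold higher number from compound 2 to compound 3 (0.01 log units; within the scatter), and a 1.2-fold lower number from compound 1 to compound 3 (0.07 log units; within the scatter). Compound 4 `COc1cc(C2=NOC(COc3ccc(-c4nnnn4-c4cc(OC)c(OC)c(OC)c4)cc3N)C2)ccc1O` has the same atoms, joined differently: 4-hydroxy-3-methoxyphenyl in place of 3-hydroxy-4-methoxyphenyl on a carbon with a double bond to nitrogen. The swap places 4-hydroxy-3-methoxyphenyl on a carbon with a double bond to nitrogen. Earlier changes at this group moved the number little: a 1.2-fold lower number from compound 1 to compound 2 (0.09 log units; within the scatter) on adding a methoxy, and the step to compound 3 above on replacing a methyl with hydrogen. Both lie within the scatter, so no shift beyond the scatter is expected here. The expected change is a 1.0-fold higher number from compound 3 to compound 4 (0.01 log units; within the scatter). For compound 4 the estimated value is 2200 nM, with an expected range of 1200 nM to 4000 nM.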

Compound 4, half-maximal inhibitory concentration: 2010 nM
Estimate against measurement, compound 4: 1.1-fold (0.04 log units) above; the measured number falls inside the stated range.
By their numbers in this assay, from the lowest: compounds 4, 2, 3 and 1 (each within the scatter of the next).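

Exchanging 3-hydroxy-4-methoxyphenyl for 4-hydroxy-3-methoxyphenyl on the carbon with a double bond to nitrogen leaves this assay flat, with a 1.1-fold lower number from compound 3 to compound 4 (0.03 log units; within the scatter) as the result. The other comparisons agree, with a 1.0-fold lower number from compound 2 to compound 4 (0.01 log units; within the scatter) and a 1.3-fold lower number from compound 1 to compound 4 (0.10 log units; within the scatter) also showing no real change, so the arrangement of hydroxy and methoxy does not matter among these compounds. Nothing measured here offers an explanation for this flatness. As far as these compounds go, whether a group of another kind at this place, such as a carboxylic acid or a longer alkyl chain, would move the number beyond the scatter remains open.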